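The compounds below may be only part of what the source reports. "The series", "measured", "known", "first", "only" and "open" are said of these compounds alone.

Values in a functional assay on A-375 cells (Homo sapiens) for cytotoxicity, read by CCK-8 assay, with a stated time of 24 h; a higher number here means a weaker inhibitor, a lower number a stronger inhibitor:
- compound 1 `COc1ccccc1Oc1c(N)nc(-c2ccccc2)nc1Cl`: 7220 nM
- compound 2 `COc1ccccc1Oc1c(N)nc(-c2ccccc2)nc1OCCO`: > 80000 nM (a limit of the assay, not a number)
- compound 3 `COc1ccccc1Oc1c(N)nc(-c2ccc(C)cc2)nc1OCCO`: not yet measured

Compound 2 stands only at a limit, > 80000 nM, and no number is known for it. Compound 3 differs from it by methyl in place of hydrogen on an aromatic carbon, phenyl to 4-methylphenyl. Among the compounds with values here, the one measured step, an at least 11-fold higher number from compound 1 to compound 2 (1.04 log units; beyond the scatter), is large, but it replaces chloro with 2-hydroxyethoxy elsewhere on the core, so it bears only indirectly on this change. In this assay, the expected step is therefore none beyond the scatter, a number no higher from compound 2 to compound 3 (the limit leaves the size open). For compound 3 the estimated value is 80000 nM, with an expected range of 30000 nM to 160000 nM.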

Compound 3, half-maximal inhibitory concentration: 2380 nM
The estimate for compound 3 lay 34-fold (1.53 log units) above the measured number; measured number below the stated range.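

In this assay, the change from phenyl to 4-methylphenyl gives an at least 33-fold lower number from compound 2 to compound 3 (1.52 log units; beyond the scatter). The earlier compounds shown here showed only a change elsewhere on the core, whereas this shows that a single methyl on this aromatic ring, with 2-hydroxyethoxy kept in place, moves the result from a limit to a number. The full size of the step stays unknown, since compound 2 stands at a limit of the assay: the limit of > 80000 nM in this assay, at which 1 of the 3 values shown sits.

The compounds shown leave open whether an ethyl, a methoxy or an amine at this place would act as methyl does. They also leave open whether methyl would have a similar effect with chloro in place of 2-hydroxyethoxy.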